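A Hydroxyl Replaces Fluorine on the Outer Ring

A few compounds are considered here, and "the series" means these few. Any claim that something is new, unique, unknown or untested is made for them only; others in the source may bear on it.

Of the compounds shown here, two built on a shared core have been tested in an assay on isolated protein for inhibition of acyl-CoA desaturase 1 (Rattus norvegicus); on this read-out higher numbers stand for weaker inhibition and lower numbers for stronger inhibition. Compound 1 `Cc1ccc(-c2ccc(-c3nc4ccc(S(C)(=O)=O)cc4[nH]3)cc2)cc1` carries a 4-methylphenyl group on its outer ring. In this assay compound 1 gives > 20000 nM, which is a limit of the assay rather than a number. Compound 2 `CS(=O)(=O)c1ccc2nc(-c3ccc(-c4cccc(F)c4)cc3)[nH]c2c1` carries a 3-fluorophenyl group at the same place, and in this assay compound 2 gives 21 nM. The step between them is an at least 950-fold lower number from compound 1 to compound 2 (2.97 log units; beyond the scatter). Compound 2 therefore holds the only number shown, the other result being a limit (the limit of > 20000 nM in this assay, at which 1 of the 2 values shown sits).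

Compound 3 `CS(=O)(=O)c1ccc2nc(-c3ccc(-c4ccccc4O)cc3)[nH]c2c1` is the unmeasured candidate. Its change from compound 2 is 2-hydroxyphenyl in place of 3-fluorophenyl on an aromatic carbon. Within the data shown here, only one measured step bears on this position, the one from compound 1 to compound 2, and it was large. It shows that this outer ring can swing the result strongly, but it compared a methyl with a fluorine, not a hydroxyl, so its direction cannot simply be carried over. A modest weakening is expected, so the step from compound 2 to compound 3 is estimated as a 7.1-fold higher number from compound 2 to compound 3 (0.85 log units; beyond the scatter). For compound 3 the estimated value is 150 nM, within a range from 25 nM to 1500 nM.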

Compound 3, half-maximal inhibitory concentration: 336 nM
The estimate for compound 3 lay 2.2-fold (0.35 log units) below the measured number, within the range that was stated.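

In this assay, the outer ring proves sensitive to more than the methyl-to-fluorine swap seen earlier: replacing 3-fluorophenyl with 2-hydroxyphenyl, which brings in a hydrogen-bond donor and a hydrogen-bond acceptor where the leaving group counts none, gives a 16-fold higher number from compound 2 to compound 3 (1.20 log units; beyond the scatter). The hydroxyl compound still keeps a measurable number, with an at least 59-fold lower number from compound 1 to compound 3 (1.77 log units; beyond the scatter), so compound 3 sits between the other two, with 3-fluorophenyl the best of the three groups on this read-out. That last step starts from a limit of the assay held by compound 1, not from a true number, so its real size stays open: the limit of > 20000 nM in this assay, at which 1 of the 3 values shown sits.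

Compound 2 and compound 3 differ both in the atom carried on the outer ring and in where that atom sits, and the compounds shown cannot tell these two changes apart. As far as these compounds go, it also remains open how this position would respond to an amine or a carboxylic acid on the outer ring, and whether either would come closer to compound 2 than the hydroxyl does.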